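Replacing Allyl(methyl)amino with (4-Fluorobenzyl)oxy on a Carbonyl

The compounds below may be only part of what the source reports. "The series", "measured", "known", "first", "only" and "open" are said of these compounds alone.

In a functional assay on PC-3 cells (Homo sapiens), read by MTT assay, with a stated time of 48 h (a higher number here means a weaker inhibitor, a lower number a stronger inhibitor), compound 1 `CCn1c(C(=O)NCCN(C)C)ccc1C(CC)(CC)c1ccc(OCC(O)C(C)(C)C)c(C)c1` gives 1630 nM and compound 2 `CCN(CC)CCCNC(=O)c1ccc(C(CC)(CC)c2ccc(OCC(O)C(C)(C)C)c(C)c2)n1CC` gives 2500 nM. These two sit close together, with a gap of a 1.5-fold higher number from compound 1 to compound 2 (0.19 log units; within the scatter). Compound 3 `C=CCN(C)C(=O)c1ccc(C(CC)(CC)c2ccc(OCC(O)C(C)(C)C)c(C)c2)n1CC` gives 25900 nM, the highest of the three numbers, which makes it the weakest inhibitor of the set. The steps leading to it are large: a 16-fold higher number from compound 1 to compound 3 (1.20 log units; beyond the scatter) and a 10-fold higher number from compound 2 to compound 3 (1.02 log units; beyond the scatter).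

Compound 4 `CCn1c(C(=O)OCc2ccc(F)cc2)ccc1C(CC)(CC)c1ccc(OCC(O)C(C)(C)C)c(C)c1` changes only the group on the carbonyl carbon, with (4-fluorobenzyl)oxy in place of allyl(methyl)amino on a carbonyl carbon. Like compound 3, compound 4 lacks the dimethylamino and diethylamino chain ends of compounds 1 and 2, so the large drop seen in those steps is not expected to reverse. Going by the values given here, no measured compound carries the incoming group, which leaves the estimate wide. In this assay, a modest 1.4-fold lower number from compound 3 to compound 4 (0.16 log units; within the scatter) is expected. Compound 4 is estimated at 18000 nM, with an expected range of 5000 nM to 50000 nM.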

Compound 4, half-maximal inhibitory concentration: > 50000 nM
Compound 4: no number, only a limit (the forecaster's own chance of this, stated with the estimate: 15%); middle value at least 2.7-fold (0.44 log units) from the limit.
By their numbers in this assay, from the lowest: compounds 1 and 2 (each within the scatter of the next); then compound 3. At a limit, above all of these: compound 4.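

In this assay compound 4 has no number, only a limit of the assay: the limit of > 50000 nM in this assay, at which 1 of the 4 values shown sits.

Even so, this result shows that a second group without a chain amine end on the carbonyl carbon stays far from the amides carrying one, with an at least 20-fold higher number from compound 2 to compound 4 (1.30 log units; beyond the scatter) and an at least 30-fold higher number from compound 1 to compound 4 (1.48 log units; beyond the scatter). The remaining step, an at least 1.9-fold higher number from compound 3 to compound 4 (0.28 log units; that floor lies within the scatter), has a floor within the scatter, so exchanging allyl(methyl)amino for (4-fluorobenzyl)oxy brings no return towards compound 1 or compound 2, although a six-membered aromatic ring enters, but the two groups are not separated from each other.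

The compounds shown leave open whether the terminal amine alone carries the difference or whether the amide hydrogen also counts. A (2-(dimethylamino)ethyl)oxy group on the same carbonyl carbon would separate these two, and a carboxylic acid there remains an open case.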